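This account rests on a few compounds, and the source may have more. Where it says the series, first, only, none or still open, it means among the compounds named here.

Measured so far in a functional assay on U-87MG ATCC cells for antiproliferative activity against U-87 MG (Homo sapiens), read by MTT assay, with a stated time of 48 h, tested at 100 uM; a lower number here means a stronger effect, a higher number a weaker effect of the compound at the concentration tested: compound 1 `Cc1nc(-c2ccccc2)sc1C(=O)CSc1nc(-c2ccccc2)c(C#N)c(=O)[nH]1` gives 9.23%; compound 2 `COc1cccc(-c2nc(SCC(=O)c3sc(-c4ccccc4)nc3C)[nH]c(=O)c2C#N)c1` gives 21.8%.

Going by the values given here, compound 2 stands highest of the two numbers, with compound 1 lower by a number 12.6 percentage points higher from compound 1 to compound 2 (beyond the scatter), the only step yet seen and the one that bears on this position. Compound 3 `Cc1nc(-c2ccccc2)sc1C(=O)CSc1nc(-c2ccc(Cl)cc2)c(C#N)c(=O)[nH]1` has not been measured. The change is 4-chlorophenyl in place of 3-methoxyphenyl on an aromatic carbon. Among the compounds with values here, the sole precedent shows that a substituent on this ring raised the reading beyond the scatter; a chlorine para on that ring has no direct precedent here. Compound 3 is therefore expected to fall between its neighbours, estimated at 13% with a range of 4% to 26%. The expected step is a number 8.8 percentage points lower from compound 2 to compound 3 (within the scatter).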

Compound 3, a percentage reported as activity, at one concentration (the size of the read-out at that concentration, not a potency): 22.5%
For compound 3 the middle estimate is 9.5 percentage points below the measured one; measured number inside the range.
By their numbers in this assay, from the lowest: compound 1; then compounds 2 and 3 (each within the scatter of the next).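

In this assay, 4-chlorophenyl in place of 3-methoxyphenyl gives a number 0.7 percentage points higher from compound 2 to compound 3 (within the scatter), so these two groups cannot be told apart at this position. Chloro in place of hydrogen gives a number 13.3 percentage points higher from compound 1 to compound 3 (beyond the scatter), which puts a second substituted phenyl on the same side of the unsubstituted phenyl of compound 1. Nothing available explains this shared shift.

Open: whether an amine or a carboxylic acid on this phenyl ring would read with compound 1 or with compound 2 and compound 3. Also open, as far as these compounds go, is whether a chloro group placed where the methoxy of compound 2 sits would read the same.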